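The compounds below may be only part of what the source reports. "The series", "measured", "known", "first", "only" and "open" are said of these compounds alone.

Compound 1 `CCC(=O)c1ccc(OCCCCOc2ccc(F)c(C(=O)O)c2)c(C)c1O` and compound 2 `Cc1c(OCCCCOc2ccc(F)c(C(=O)O)c2)ccc(C(=O)C(C)C)c1O` share one core. In an assay on HEK293 cells for positive allosteric modulation of metabotropic glutamate receptor 3 (Rattus norvegicus), read by thallium flux, with a stated time of 2.5 min (on this read-out lower numbers stand for smaller maximal responses and higher numbers for larger maximal responses), compound 1 gives 18.4%, and compound 2 gives 31.3%. The two differ by methyl in place of hydrogen on a saturated chain carbon bound to a carbonyl carbon and a saturated chain carbon, and that change made a number 12.9 percentage points higher from compound 1 to compound 2 (beyond the scatter). Compound 3 `COc1cc(C(=O)O)ccc1OCCCCOc1ccc(C(C)=O)c(O)c1C` is built on another core, and the difference between the two cores is not broken down here; in this assay compound 3 gives 26.3%. Compound 4 `CCC(=O)c1ccc(OCCCCOc2ccc(C(=O)O)cc2OC)c(C)c1O` has not yet been measured. It differs from compound 3 by methyl in place of hydrogen on a saturated chain carbon bound to a carbonyl carbon, the same kind of change as before, though here the saturated chain carbon is bound to a carbonyl carbon only, not also to a saturated chain carbon. Because the earlier change made a number 12.9 percentage points higher from compound 1 to compound 2 (beyond the scatter), a step of a number 9.7 percentage points higher from compound 3 to compound 4 (within the scatter) is expected. Compound 4 is therefore estimated to reach 36% in this assay, most likely between 22% and 50%.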

Compound 4, largest response reached (reported as percent of maximum), in percent of the reference or control that the assay uses: 25.9%
Beside the measured number, compound 4's estimate is 10.1 percentage points above it, and the stated range covers the measured number.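

In this assay, turning acetyl into propanoyl gave a number 0.4 percentage points lower from compound 3 to compound 4 (within the scatter), so the rise seen on the core of compound 1 did not clearly reappear on this core. Set side by side, the two steps cannot be told apart: the same change on two cores in this assay, a number 12.9 percentage points higher (beyond the scatter) from compound 1 to compound 2 and a number 0.4 percentage points lower (within the scatter) from compound 3 to compound 4, 13.3 percentage points apart, within the scatter of two such steps This shows neither that the change carries over from one core to the other nor that its effect depends on the core, since a single step on each core is too little to decide either way.

Still open, as far as these compounds go, is how the branched carbonyl group of compound 2 would behave on the core of compound 3. Also open, from the compounds shown here alone, is what a longer chain, such as butanoyl, would do on either core.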